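This account rests on a few compounds, and the source may have more. Where it says the series, first, only, none or still open, it means among the compounds named here.

Of the compounds shown here, three of a shared core have been tested in a functional assay on the whole organism (strain Swiss) with Mus musculus as the target, in the maximal electroshock model, with a stated time of 1 h, at a dose of 300 mg/kg by the intraperitoneal route; on this read-out lower numbers stand for a weaker effect and higher numbers for a stronger effect at the one dose given. Compound 3 `CC(C(=O)N1CCN(c2cccc(Cl)c2)CC1)N1C(=O)CCC1=O` gives 75%, and compound 2 `CCC(C(=O)N1CCN(c2cccc(Cl)c2)CC1)N1C(=O)CCC1=O` gives 100%. These two differ only in their core: compound 2 carries methyl in place of hydrogen on a saturated chain carbon, two bonds along the chain from an amide-type nitrogen in a ring and a carbonyl carbon. On the whole-organism read-out, the step of a number 25 percentage points lower from compound 2 to compound 3 (beyond the scatter) is modest.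

Compound 1 `CC(C(=O)N1CCN(c2ccc(Cl)cc2)CC1)N1C(=O)CCC1=O` gives 0%. It is built from compound 3 by one change, (4-chlorophenyl in place of 3-chlorophenyl on an amine nitrogen in a ring), and the step of a number 75 percentage points lower from compound 3 to compound 1 (beyond the scatter) is large.

Compound 4 `CCC(C(=O)N1CCN(c2ccc(Cl)cc2)CC1)N1C(=O)CCC1=O` has not yet been measured in this assay. It stands to compound 2 as compound 1 stands to compound 3: the change is 4-chlorophenyl in place of 3-chlorophenyl on an amine nitrogen in a ring, the same change on the same place, made this time on the core of compound 2. Because compound 3 fell to compound 1 by a number 75 percentage points lower from compound 3 to compound 1 (beyond the scatter), a step of similar size downward is expected from the high value of compound 2, so that the expected step is a number 75 percentage points lower from compound 2 to compound 4 (beyond the scatter). Compound 4 is therefore estimated at 25%, with a likely range from 0% to 60%. For the measured compounds named here, this rests on only one earlier instance of the change, so the real number may sit elsewhere.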

Compound 4, a percentage reported as activity, at one dose (the size of the read-out at that dose, not a potency): 25%
Compound 4: the middle estimate sits on the measured number at the digits printed; the measured number falls inside the stated range.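

In this assay, 4-chlorophenyl in place of 3-chlorophenyl has the same effect on the core of compound 2 (a number 75 percentage points lower from compound 2 to compound 4 (beyond the scatter)) as it had on the core of compound 3, so in this series the change carries from one core to the other without a visible shift in size: the same change on two cores in this assay, a number 75 percentage points lower (beyond the scatter) from compound 3 to compound 1 and a number 75 percentage points lower (beyond the scatter) from compound 2 to compound 4, 0 percentage points apart, within the scatter of two such steps. The methyl in place of hydrogen on the saturated chain carbon also carries over (a number 25 percentage points higher from compound 1 to compound 4 (beyond the scatter)), so the two changes behave independently across these four compounds: the same change on two cores in this assay, a number 25 percentage points lower (beyond the scatter) from compound 2 to compound 3 and a number 25 percentage points lower (beyond the scatter) from compound 4 to compound 1, 0 percentage points apart, within the scatter of two such steps. This does not show that either change would behave the same way on any other core, since each rests on a single pair of cores, and a reading at one dose does not measure potency.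

The compounds shown leave open how a phenyl ring bearing fluorine or a methoxy group in place of chlorine would fare. They also leave open whether a longer chain on that saturated carbon would keep the effect.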